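Changing the Ring Group on Compound 3

The source may report more compounds than this note shows. Statements on the series, on what has been measured and on what is new or still open speak of the compounds shown alone.

Of the compounds shown here, three have been tested so far in a functional assay on HGC-27 cells (Homo sapiens) for antiproliferative activity, read by MTT assay, with stated times of 72 h and 4 h; a lower number here means a stronger inhibitor, a higher number a weaker inhibitor. Compound 3 `COc1ncc(-c2nc3c(N4CCCCC4)ncnc3s2)cc1NS(=O)(=O)c1ccc(F)cc1F` gives 960 nM, the highest number of the three, which makes it the weakest inhibitor here. Compound 1 `COc1ncc(-c2cc3c(N4CC5COCC5C4)ncnc3s2)cc1NS(=O)(=O)c1ccc(F)cc1F` gives 300 nM, and compound 2 `COc1ncc(-c2nc3c(N4CC(C)OC(C)C4)ncnc3s2)cc1NS(=O)(=O)c1ccc(F)cc1F` gives 270 nM.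

Compound 4 `COc1ncc(-c2nc3c(N4CC5CCCC5C4)ncnc3s2)cc1NS(=O)(=O)c1ccc(F)cc1F` keeps the core of compound 3 and changes one group: a group of 8 heavy atoms (7 carbon, 1 nitrogen; one five-membered non-aromatic ring of carbon only, one five-membered non-aromatic ring with 1 hetero atom) in place of a group of 6 heavy atoms (5 carbon, 1 nitrogen; one six-membered non-aromatic ring with 1 hetero atom), on an aromatic carbon. For the measured compounds named here, one measured step touches this same position: a 3.6-fold higher number from compound 2 to compound 3 (0.55 log units; beyond the scatter), a modest change that arose when piperidin-1-yl replaced 2,6-dimethylmorpholin-4-yl. Piperidin-1-yl therefore sits at the weak end of what has been seen. Compound 1, at 300 nM, carries a related group on this carbon, but its core differs, so it offers only loose support. Going by the values given here, no measured step makes this exact change, so a modest move towards a lower number in this assay is only a tentative expectation. The expected step is a 1.8-fold lower number from compound 3 to compound 4 (0.27 log units; within the scatter). Compound 4 is estimated at 520 nM, with an expected range of 200 nM to 1300 nM.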

Compound 4, half-maximal inhibitory concentration: 310 nM
Compound 4: the middle estimate sits 1.7-fold (0.22 log units) above what was measured, and the stated range covers the measured number.
By their numbers in this assay, from the lowest: compounds 2, 1 and 4 (each within the scatter of the next); then compound 3.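

In this assay, putting the fused two-ring group in place of piperidin-1-yl gives a 3.1-fold lower number from compound 3 to compound 4 (0.49 log units; beyond the scatter), so piperidin-1-yl is now set apart from two different groups on this aromatic carbon of the shared core. Against 2,6-dimethylmorpholin-4-yl, the same group gives a 1.1-fold higher number from compound 2 to compound 4 (0.06 log units; within the scatter), which means that these two groups of equal heavy-atom count cannot be told apart here, even though the new one contains no oxygen. Nothing available explains why either group differs from piperidin-1-yl.

Going by these compounds, it remains open whether pyrrolidin-1-yl, or morpholin-4-yl without its two methyl groups, would sit with piperidin-1-yl or with the two larger groups. On these data alone, how piperazin-1-yl, with a second ring nitrogen, would behave on this carbon is also open.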